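From 4-Cyanobenzyl to 4-Methoxybenzyl

The source may hold more compounds than are shown below. What is called first, only, known or untested is meant among the compounds shown, and "the series" means these compounds.

In a functional assay on MOLT-4 cells (Homo sapiens) for inhibition, read by MTT assay, with a stated time of 48 h (a higher number here means a weaker inhibitor, a lower number a stronger inhibitor), compound 1 `O=C(/C=C/c1cn(Cc2ccc(Cl)cc2)c2ccccc12)CC(=O)C(=O)O` gives 19000 nM. Compound 2 `N#Cc1ccc(Cn2cc(/C=C/C(=O)CC(=O)C(=O)O)c3ccccc32)cc1`, which carries a 4-cyanobenzyl group, gives > 40000 nM in this assay, and this is a limit of the assay and not a number. Compound 3 `COc1ccc(Cn2cc(/C=C/C(=O)CC(=O)C(=O)O)c3ccccc32)cc1` has yet to be measured. It differs from compound 2 at one place, with methoxy in place of cyano on an aromatic carbon, para to a large group: methoxy in place of cyano on an aromatic carbon.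

Going by the values given here, only one measured step bears on this change, the replacement of chloro by cyano at the same place. It gave an at least 2.1-fold higher number from compound 1 to compound 2 (0.32 log units; beyond the scatter), which lies beyond the scatter but has no upper bound. Methoxy has not been tested here, so the step offers only a loose guide. Compound 1 with 19000 nM shows that a group other than cyano at this place can give a measurable value, so a modest move to a lower number is expected. This expected move is an at least 1.8-fold lower number from compound 2 to compound 3 (0.25 log units; that floor lies within the scatter). Compound 3 is estimated at 22000 nM, with an expected range of 10000 nM to 40000 nM.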

Compound 3, half-maximal inhibitory concentration: > 40000 nM
Compound 3 ended at the assay's limit; the forecaster's own chance of this, stated with the estimate: 30%; middle value at least 1.8-fold (0.25 log units) from the limit.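

In this assay, methoxy in place of chloro on the aromatic carbon gives an at least 2.1-fold higher number from compound 1 to compound 3 (0.32 log units; beyond the scatter), and this matches the lower bound of the earlier change, an at least 2.1-fold higher number from compound 1 to compound 2 (0.32 log units; beyond the scatter). The loss of a measurable value on leaving chloro is therefore no longer tied to cyano alone: of the three compounds, only compound 1, the 4-chlorobenzyl compound, gives a value that can be read as a number. The step between compound 2 and compound 3 cannot be read, and cyano and methoxy cannot be ranked against each other, as each compound has only a limit of the assay and not a number: the limit of > 40000 nM in this assay, at which 2 of the 3 values shown sit.

As far as these compounds go, how far compound 2 and compound 3 lie past that limit stays open, and so does whether the two steps from compound 1 differ in true size. Also open, from the compounds shown here alone, is whether chloro is unusual at this place, or whether another group there, such as bromo, an amine or a carboxylic acid, would also give a readable value.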